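The compounds below may be only part of what the source reports. "The series", "measured", "known", "first", "only" and "open" are said of these compounds alone.

Compound 1 `NC(=O)c1ccc(Cn2cc(-c3ccc4cn[nH]c4c3)ccc2=O)cc1` gives > 2000 nM in an assay for inhibition of MAP kinase-interacting serine/threonine-protein kinase 1 (Homo sapiens), read by luminescence and ADP-Glo, with a stated time of 2 h (on this read-out lower numbers stand for stronger inhibition and higher numbers for weaker inhibition), which is a limit of the assay and not a number.
Compound 2 `CC(=O)Nc1cccc(Cn2cc(-c3ccc4c(N)n[nH]c4c3)ccc2=O)c1` gives 55 nM in this assay.
Compound 3 `Nc1n[nH]c2cc(-c3ccc(=O)n(Cc4cccc(C(F)(F)F)c4)c3)ccc12` gives 56 nM in this assay.

Compound 1 therefore stands only at a limit of this assay, with no number of its own. Compound 4 `O=c1ccc(-c2ccc3cn[nH]c3c2)cn1Cc1ccc(C(F)(F)F)cc1` differs from it by trifluoromethyl in place of carbamoyl on an aromatic carbon. Among the compounds with values here, the single measured step, a 1.0-fold higher number from compound 2 to compound 3 (0.01 log units; within the scatter), exchanges a different group on a core unlike that of compound 1 and lies within the scatter, so it gives no sign that a trifluoromethyl group on its own moves potency. Given compound 1 sits at the limit of > 2000 nM in this assay, at which 1 of the 3 values shown sits, compound 4 is expected to remain weak, with a step that the limit leaves unreadable from compound 1 to compound 4 not expected to exceed the scatter. The estimate for compound 4 is 3000 nM, between 1200 nM and 10000 nM, most likely reported again only as a limit.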

Compound 4, half-maximal inhibitory concentration: 1170 nM
Compound 4: the middle estimate sits 2.6-fold (0.41 log units) above what was measured, outside the stated range (below it).
By their numbers in this assay, from the lowest: compounds 2 and 3 (each within the scatter of the next); then compound 4. At a limit, above all of these: compound 1.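

Trifluoromethyl in place of carbamoyl, on an aromatic carbon para to a large group, gives an at least 1.7-fold lower number from compound 1 to compound 4 (0.23 log units; that floor lies within the scatter) in this assay. On this core, compound 4 gives a measured number, 1170 nM. Compound 1 stands at a limit of the assay, so only a floor can be read for the step, and its full size stays unknown: the limit of > 2000 nM in this assay, at which 1 of the 4 values shown sits.

The compounds shown leave open how an amine or a carboxylic acid would read at this place. They also leave open how the same exchange would read on the core of compound 3.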